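From 4-Methoxyphenyl to 3-Methoxyphenyl: Expected Cytotoxicity

A few compounds are considered here, and "the series" means these few. Any claim that something is new, unique, unknown or untested is made for them only; others in the source may bear on it.

Compound 1 `O=C(COc1ccc(/C=C/C(=O)c2ccc(F)cc2)cc1)Nc1ccc2c(c1)COC2=O` and compound 2 `COc1ccc(/C=C/C(=O)c2ccc(OCC(=O)Nc3ccc4c(c3)COC4=O)cc2)cc1` share one core and differ in a single aromatic ring. In an ADME assay on NIH3T3 cells (Mus musculus) for cytotoxicity, read by MTT assay, with a stated time of 48 h, tested at 10 uM (on this read-out lower numbers stand for a stronger effect and higher numbers for a weaker effect at the one concentration tested), compound 1 gives 90.3%, and compound 2 gives 90.9%. Compound 2 and compound 1 lie within the scatter of each other, so neither can be set apart on these numbers.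

Compound 3 `COc1cccc(/C=C/C(=O)c2ccc(OCC(=O)Nc3ccc4c(c3)COC4=O)cc2)c1` is not yet measured; it keeps every atom of compound 2, joined differently: 3-methoxyphenyl in place of 4-methoxyphenyl on a double-bonded chain carbon bound to a double-bonded chain carbon. Going by the values given here, no step between measured compounds is available to scale this change, so a step of a number 0.9 percentage points lower from compound 2 to compound 3 (within the scatter) is expected, none beyond the scatter. Compound 3 is estimated at 90%, within 80% to 100%.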

Compound 3, a percentage reported as activity, at one concentration (the size of the read-out at that concentration, not a potency): 87.1%
Estimate against measurement, compound 3: 2.9 percentage points above, within the range that was stated.
By their numbers in this assay, from the lowest: compounds 3, 1 and 2 (each within the scatter of the next).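

Putting 3-methoxyphenyl in place of 4-methoxyphenyl on a double-bonded chain carbon bound to a double-bonded chain carbon gives, in this assay, a number 3.8 percentage points lower from compound 2 to compound 3 (within the scatter). This position therefore tolerates this rearrangement of the same atoms without a change that can be told from the scatter, at the one concentration tested. Nothing available explains the result.

As far as these compounds go, whether an amine or a carboxylic acid in place of the methoxy group would give a step beyond the scatter stays open. So does the effect of a longer chain in place of the ethenyl link.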